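Swapping a methyl-bearing ring for a halogen-bearing one

The source may report more compounds than this note shows. Statements on the series, on what has been measured and on what is new or still open speak of the compounds shown alone.

Going by the values given here, compound 1, with the structure `C=CCn1c(=O)/c(=C\c2cccc(C)c2)[nH]c(=O)/c1=C\c1ccccc1OC`, is the only member of this small set to return a number: in a functional assay on U-937 cells (Homo sapiens) for cytotoxicity, read by CCK-8 assay, with a stated time of 72 h (a higher number here means a weaker inhibitor, a lower number a stronger inhibitor), compound 1 gives 5100 nM, a weak result. Compound 2 `C=CCn1c(=O)/c(=C\c2ccc(F)c(Br)c2)[nH]c(=O)/c1=C\c1ccccc1OC` was reported in this assay as "not active" (no number reported), and compound 3 `COc1ccccc1/C=c1/[nH]c(=O)/c(=C\c2cccc(Cl)c2Cl)[nH]c1=O` likewise as "not active" (no number reported), so compound 1 stands alone with a measured value. Compound 4, with the structure `C=CCn1c(=O)/c(=C\c2cc(Br)ccc2F)[nH]c(=O)/c1=C\c1ccccc1OC`, is not yet measured. It differs from compound 1 as follows: 5-bromo-2-fluorophenyl in place of 3-methylphenyl on a double-bonded chain carbon bound to an aromatic carbon. Since compound 2, which also carries a bromine and a fluorine, gave no number, the step expected from compound 1 to compound 4 is a loss, a 2.9-fold higher number from compound 1 to compound 4 (0.47 log units; beyond the scatter), with a real chance that no number is reported. Compound 4 is estimated at 15000 nM, within 5000 nM to 50000 nM.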

Compound 4, half-maximal inhibitory concentration: 4700 nM
Beside the measured number, compound 4's estimate is 3.2-fold (0.50 log units) above it, and the stated range ends above it.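

In this assay, the swap gives a 1.1-fold lower number from compound 1 to compound 4 (0.04 log units; within the scatter), so this position takes 5-bromo-2-fluorophenyl in place of 3-methylphenyl without a real change. Bromine and fluorine on this ring therefore do not always go with a "not active" report: compound 2, which carries both, received that report, while compound 4 returned a number, although no step involving compound 2 can be read. No data shown here bear on the reason for this result.

As far as these compounds go, whether an amine or a carboxylic acid on this ring would keep a measurable value remains open. So does whether any group at this position can give a clearly lower number than compound 1.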